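This account rests on a few compounds, and the source may have more. Where it says the series, first, only, none or still open, it means among the compounds named here.

The measured compounds in this study:

Compound 1, `Cc1noc(NS(=O)(=O)c2cccc([N+](=O)[O-])c2)c1C`: 7800 nM
Compound 2, `Cc1noc(NS(=O)(=O)c2cccc3c(NC(=O)C(C)C)cccc23)c1C`: 880 nM

Both numbers come from an assay on VSM-A10 cells for antagonist activity at Endothelin-1 receptor (Rattus norvegicus); on this read-out lower numbers stand for stronger inhibition and higher numbers for weaker inhibition. Of the two, compound 1 stands at the higher number, so it is the weaker inhibitor of the pair; compound 2 sits at a lower number, and the gap between them is beyond the usual scatter of this measurement. Compound 2 is built on a different aromatic part, so no single structural change between these two is described here, and only their two values can be compared.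

Compound 3, `Cc1noc(NS(=O)(=O)c2cccc(-c3ccccc3)c2)c1C`, has not been measured yet. It differs from compound 1 in one place: phenyl in place of nitro on an aromatic carbon, meta to a large group. Going by the values given here, no measured pair shows this exact change, so the size of the step can only be guessed. Compound 3 is expected to move toward a lower number, by a step of about a 3.1-fold lower number from compound 1 to compound 3 (0.49 log units; beyond the scatter). For compound 3 the estimated value in this assay is 2500 nM, with a likely range from 600 nM to 10000 nM.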

Compound 3, half-maximal inhibitory concentration: 5400 nM
Estimate against measurement, compound 3: 2.2-fold (0.33 log units) below, within the range that was stated.
By their numbers in this assay, from the lowest: compound 2; then compounds 3 and 1 (each within the scatter of the next).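

Replacing nitro with phenyl at this spot on the aromatic ring gives, in this assay, a 1.4-fold lower number from compound 1 to compound 3 (0.16 log units; within the scatter), so the two compounds cannot be told apart in this measurement. The swap is not a small one on paper: 3 heavy atoms with 2 hydrogen-bond acceptors leave, and 6 carbon atoms forming a whole aromatic ring with no hydrogen-bond acceptors enter, yet the read-out stays within its usual scatter, so at this position these two very different groups give no measurable difference. No separate measurement is available here that would explain this result.

Going by these compounds alone, only two groups have been compared at this position, so it remains open whether an amine, a carboxylic acid or a longer alkyl chain in the same place would give a value clearly different from these two. It also remains open whether phenyl would give the same result if attached at a different carbon of the ring, since the compounds shown compare it at only this one place.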